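Lengthening the chain that carries the methylpiperazine

The source may hold more compounds than are shown below. What is called first, only, known or untested is meant among the compounds shown, and "the series" means these compounds.

Of the compounds shown here, three that share one core have been measured in a functional assay on MCF7 cells (Homo sapiens) for cytotoxicity, read by MTT assay, with a stated time of 72 h; a higher number here means a weaker inhibitor, a lower number a stronger inhibitor. Compound 1 `O=C1c2c[n+]([O-])c3ccccc3c2C(=O)c2c1c1ccccc1n2Cc1cn([C@H]2O[C@H](CO)[C@@H](O)[C@H]2O)nn1` gives 1490 nM and compound 3 `CC1(C)OC[C@H](Cn2cc(Cn3c4c(c5ccccc53)C(=O)c3c[n+]([O-])c5ccccc5c3C4=O)nn2)O1` gives 530 nM. Compound 2 `CN1CCN(CCCCn2c3c(c4ccccc42)C(=O)c2c[n+]([O-])c4ccccc4c2C3=O)CC1` gives 100 nM, the lowest number of the three and beyond the scatter of both others.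

Compound 4 `CN1CCN(CCCCCCn2c3c(c4ccccc42)C(=O)c2c[n+]([O-])c4ccccc4c2C3=O)CC1` is the next to be read. It differs from compound 2 only in the chain that carries the 4-methylpiperazin-1-yl group: 2-(4-methylpiperazin-1-yl)ethyl in place of 4-methylpiperazin-1-yl on a saturated chain carbon, four bonds along the chain from an aromatic nitrogen. In words, 2-(4-methylpiperazin-1-yl)ethyl stands in place of 4-methylpiperazin-1-yl on a saturated chain carbon, four bonds along the chain from an aromatic nitrogen.

Within the data shown here, only one measured step isolates a single change, a 2.8-fold lower number from compound 1 to compound 3 (0.45 log units; beyond the scatter), and it is modest. That step swaps 3,4-dihydroxy-5-(hydroxymethyl)oxolan-2-yl for (2,2-dimethyl-1,3-dioxolan-4-yl)methyl, so it bears only loosely on this question. Among the measured compounds shown here, no measured pair differs in chain length alone, and the direction of any shift therefore remains open. The modest size of that one step gives no ground for expecting a large move in this assay. An estimated 1.1-fold lower number from compound 2 to compound 4 (0.05 log units; within the scatter) is expected, which stays within the scatter. Compound 4 is expected at 90 nM, with an estimated range of 30 nM to 280 nM.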

Compound 4, half-maximal inhibitory concentration: 400 nM
Compound 4: the middle estimate sits 4.4-fold (0.65 log units) below what was measured; the whole stated range lies below it.
By their numbers in this assay, from the lowest: compound 2; then compounds 4 and 3 (each within the scatter of the next); then compound 1.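

In this assay, among these compounds, lengthening the chain gives a 4.0-fold higher number from compound 2 to compound 4 (0.60 log units; beyond the scatter), the first measured step to isolate the length of the chain that carries the 4-methylpiperazin-1-yl group. It shows that this position is sensitive to chain length in this assay: the ring at the end of the chain stays the same, the hydrogen-bond donor and acceptor counts and the absence of net charge are unchanged, and the two extra chain carbons alone separate the pair by more than the scatter. Nothing measured here accounts for the shift, so its cause stays unknown.

With only these two chain lengths carrying this ring, the compounds shown cannot say whether the number rises steadily with length or passes through a minimum, which a pentyl chain or a shorter propyl chain would help to settle. They also leave open whether the same step would appear with a morpholine or a dimethylamino group at the end of the chain in place of the 4-methylpiperazin-1-yl group.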